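A few compounds are considered here, and "the series" means these few. Any claim that something is new, unique, unknown or untested is made for them only; others in the source may bear on it.

The compounds measured in an assay on isolated protein for inhibition of Leucine-rich repeat serine/threonine-protein kinase 2 variant G2019S (Homo sapiens), read by TR-FRET and LanthaScreen, with stated times of 50 min and 30 min, in the presence of a further agent that is not named here (a lower number here means a stronger inhibitor, a higher number a weaker inhibitor), are:

compound 1 `Cc1c(Nc2nc(N)c3c(C#N)c(N4CCC[C@H]4C)n(C)c3n2)cnn1CC(C)(C)O` with 35 nM
compound 2 `Cc1cn(C)nc1Nc1cc2c(c(N)n1)c(C#N)c(N1CCC[C@H]1C)n2C` with 1290 nM
compound 3 `Cn1c(NCc2ccccc2F)c(C#N)c2c(N)ncnc21` with 1740 nM

Compound 1 has the lowest number of the three in this assay. Its nearest neighbour is compound 2, whose number is higher by a gap that lies beyond the scatter of repeated measurements, and compound 3 lies further still, also beyond the scatter. Compound 1 is therefore the strongest inhibitor of the three in this assay. Going by the values given here, compound 2 and compound 3 differ from it in more than one place, so no single step between measured compounds can be isolated here, and only their values themselves can be set beside one another.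

The account now turns to compound 4 `Cc1c(Nc2nc(N)c3c(C#N)c(N4CCC[C@H]4C)n(C)c3n2)cnn1[C@H]1CCOC1`, which has not yet been measured in this assay. Compound 4 differs from compound 1 in one place: oxolan-3-yl in place of 2-hydroxy-2-methylpropyl on an aromatic nitrogen. Both groups have the same number of heavy atoms and the same single oxygen, but the hydrogen-bond donor of compound 1 is lost and a ring with a defined stereocentre is gained.

Among the compounds with values here, since no measured pair in this set shows what such an exchange does, the expectation rests on compound 1 alone. The step from compound 1 to compound 4 is expected to be small, most likely none beyond the scatter, giving a 1.1-fold higher number from compound 1 to compound 4 (0.06 log units; within the scatter). Compound 4 is thus estimated at 40 nM in this assay, with a range from 12 nM to 130 nM.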

Compound 4, half-maximal inhibitory concentration: 14 nM
Estimate against measurement, compound 4: 2.9-fold (0.46 log units) above, within the range that was stated.
By their numbers in this assay, from the lowest: compound 4; then compound 1; then compounds 2 and 3 (each within the scatter of the next).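

In this assay, going by these compounds alone, the exchange of 2-hydroxy-2-methylpropyl for oxolan-3-yl on the aromatic nitrogen gives a 2.5-fold lower number from compound 1 to compound 4 (0.40 log units; beyond the scatter) and is the first step in this set that can be read at one place. It shows that this position responds to a change of substituent even when the number of heavy atoms and the single oxygen stay the same, and that the hydrogen-bond donor of compound 1 is not required for a low number, as compound 4 has no donor in this group and gives 14 nM. Nothing measured here explains why the number falls with this exchange.

The single step changes several things at once, as the donor is lost while a ring and a defined stereocentre are gained, so the compounds shown do not separate these contributions, and they include neither the opposite stereoisomer of oxolan-3-yl nor a ring without oxygen such as cyclopentyl. They also leave open how a basic amine such as piperidin-4-yl, or a longer chain ending in a hydroxyl, would fare on this nitrogen.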